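Anilino series: halogen versus alkyl at the remote position

A few compounds are considered here, and "the series" means these few. Any claim that something is new, unique, unknown or untested is made for them only; others in the source may bear on it.

Measured compounds:
Compound 1, `O=C1C=C(Nc2ccc(I)cc2)C(=O)c2c1nc1n2[C@H]2OC[C@@H](O)[C@H]2OC1` — 4070 nM
Compound 2, `COc1cccc(NC2=CC(=O)c3nc4n(c3C2=O)[C@H]2OC[C@@H](O)[C@H]2OC4)c1` — 4280 nM
Compound 3, `CCCc1ccc(NC2=CC(=O)c3nc4n(c3C2=O)[C@H]2OC[C@@H](O)[C@H]2OC4)cc1` — 4990 nM

All three share one core and differ only in the group on the amine nitrogen. In a functional assay on HeLa cells (Homo sapiens) for inhibition, read by sulforhodamine B assay (a lower number here means a stronger inhibitor, a higher number a weaker inhibitor), compound 3 gives the highest of the three numbers, yet it lies within the scatter of both neighbours: a 1.2-fold higher number from compound 2 to compound 3 (0.07 log units; within the scatter) and a 1.2-fold higher number from compound 1 to compound 3 (0.09 log units; within the scatter). No ordering among the three is supported.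

Compound 4, `O=C1C=C(Nc2ccc(Br)cc2)C(=O)c2c1nc1n2[C@H]2OC[C@@H](O)[C@H]2OC1`, is not yet measured. Against compound 3 the change is bromo in place of propyl on an aromatic carbon. The step that bears on it most directly is the one from a halogen to propyl at the same place, a 1.2-fold higher number from compound 1 to compound 3 (0.09 log units; within the scatter), which stayed within the scatter; the change of the whole ring substituent, a 1.2-fold higher number from compound 2 to compound 3 (0.07 log units; within the scatter), did the same. Nothing in the series moves the number beyond the scatter, so for the return from propyl to a halogen no step beyond the scatter is expected in this assay: a 1.2-fold lower number from compound 3 to compound 4 (0.06 log units; within the scatter) is the expected size. Compound 4 is therefore estimated at 4300 nM, with a range from 2500 nM to 7500 nM.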

Compound 4, half-maximal inhibitory concentration: 3830 nM
Compound 4: middle estimate off by 1.1-fold (0.05 log units), on the high side, and the stated range covers the measured number.
By their numbers in this assay, from the lowest: compounds 4, 1, 2 and 3 (each within the scatter of the next).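

Swapping one halogen for another at this position now has a direct reading in this assay: bromo in place of iodo gives a 1.1-fold lower number from compound 1 to compound 4 (0.03 log units; within the scatter), so the identity of the halogen does not separate compound 1 and compound 4. Propyl and bromo are also compared directly, with a 1.3-fold lower number from compound 3 to compound 4 (0.11 log units; within the scatter), and the change of the whole ring substituent gives a 1.1-fold lower number from compound 2 to compound 4 (0.05 log units; within the scatter), so all four groups on the amine nitrogen remain unresolved and no ordering among them is supported. No evidence is available that explains this flat result.

From the compounds shown here alone, whether an amine, a carboxylic acid or a longer chain in place of bromo would move the number beyond the scatter stays open. So does whether the flat picture would hold for a ring without any substituent.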